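This account rests on a few compounds, and the source may have more. Where it says the series, first, only, none or still open, it means among the compounds named here.

Measured so far:
compound 1, `Cc1ccc(/C=C(/Sc2ccc(F)cc2)C(=O)c2ccc(Cl)cc2)s1`: 25000 nM
compound 2, `Cc1ccc(CS/C(=C/c2ccc(F)c([N+](=O)[O-])c2)C(=O)c2ccc(C(=O)O)cc2)cc1`: 1000 nM

In a functional assay on DU-145 cells (Homo sapiens) for inhibition, read by trypan blue exclusion, with a stated time of 96 h (on this read-out higher numbers stand for weaker inhibition of growth and lower numbers for stronger inhibition of growth), compound 1 gives 25000 nM, the weaker of the two results, while compound 2 gives 1000 nM, a gap well beyond the usual scatter. Compound 2 differs from compound 1 in several places at once, so it offers only a loose guide. Compound 3, `Cc1ccc(/C=C(/SCc2ccc(Cl)cc2Cl)C(=O)c2ccc(Cl)cc2)s1`, is not yet measured and differs from compound 1 in one place: 2,4-dichlorobenzyl in place of 4-fluorophenyl on a sulfur. A modest gain in growth inhibition is expected, a 2.5-fold lower number from compound 1 to compound 3 (0.40 log units; beyond the scatter). Compound 3 is therefore estimated at 10000 nM, with a likely range from 2500 nM to 40000 nM.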

Compound 3, concentration for 50% growth inhibition: 50000 nM
Compound 3: the middle estimate sits 5.0-fold (0.70 log units) below what was measured, and the stated range ends below it.
By their numbers in this assay, from the lowest: compound 2; then compounds 1 and 3 (each within the scatter of the next).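

In this assay, placing 2,4-dichlorobenzyl on the sulfur in place of 4-fluorophenyl gives a 2.0-fold higher number from compound 1 to compound 3 (0.30 log units; within the scatter). At this position, then, a group with more heavy atoms, two chlorines and no fluorine is tolerated with no difference that rises above the usual scatter. No supporting measurement is available to explain this result.

This single step cannot separate the role of the benzyl carbon from that of the halogens on the ring. On these data alone, whether an amine or a longer chain on this sulfur would alter growth inhibition remains open.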